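Tetrazole series: thiazolyl swap on the five-membered core

The source may report more compounds than this note shows. Statements on the series, on what has been measured and on what is new or still open speak of the compounds shown alone.

Measured compounds:
compound 1 `Cc1c[nH]c(-c2nnn(-c3cc(F)cc(C#N)c3)n2)n1` 19 nM
compound 2 `Cc1ccncc1-c1cc(F)cc(-n2nnc(-c3ccccn3)n2)c1` 1.8 nM
compound 3 `N#Cc1cccc(-n2nnc(-c3cscn3)n2)c1` 157 nM

In an assay for binding affinity to metabotropic glutamate receptor 5 (Rattus norvegicus) (a higher number here means a weaker inhibitor, a lower number a stronger inhibitor), compound 3 gives 157 nM, the highest of the three numbers. Its nearest neighbour is compound 1, which gives 19 nM, a gap beyond the scatter. Compound 2 is furthest off at 1.8 nM, again beyond the scatter. Both other compounds differ from compound 3 in more than one place, so only their values, not single steps, can be read from them.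

Compound 4 `N#Cc1cccc(-n2nnc(-c3nccs3)n2)c1` has not yet been measured in this assay. It is built from the same atoms as compound 3, joined differently: 1,3-thiazol-2-yl in place of 1,3-thiazol-4-yl on an aromatic carbon. Nothing else changes; the nitrile-bearing ring and the core are kept.

Among the measured compounds shown here, with no step between measured compounds that isolates this change, the expectation rests on the spread of the series alone. Compound 3 sits at the weak end, and the two stronger compounds carry other five- or six-membered groups on the same position of the core. A moderate move downward in this assay is expected, of about a 2.6-fold lower number from compound 3 to compound 4 (0.42 log units; beyond the scatter), but a result within the scatter would not surprise. Compound 4 is estimated at 60 nM, with a range from 15 nM to 300 nM.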

Compound 4, inhibition constant: 183 nM
For compound 4 the middle estimate is 3.1-fold (0.48 log units) below the measured one, and the stated range covers the measured number.
By their numbers in this assay, from the lowest: compound 2; then compound 1; then compounds 3 and 4 (each within the scatter of the next).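

In this assay, among the compounds shown here, 1,3-thiazol-2-yl in place of 1,3-thiazol-4-yl on this aromatic carbon of the core gives a 1.2-fold higher number from compound 3 to compound 4 (0.07 log units; within the scatter), the first single-place step at this position. With the nitrile-bearing ring and the core kept, the two thiazolyl isomers are therefore not told apart in this read-out, so at least this reconnection of the same atoms leaves the number unmoved beyond the scatter. No measurement here bears on why the two isomers behave alike.

Going by these compounds, what the position does with anything other than a thiazolyl group remains open: a single-place step from compound 3 to a phenyl ring, an oxazolyl ring or a non-aromatic group such as an amine would show how much of the value depends on this substituent at all. Also open, on these data alone, is whether the same isomer swap stays within the scatter when the aryl ring on the core carries a fluorine, as it does in compound 1 and compound 2, or when the thiazole itself bears a methyl group.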